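Crotonamide in place of propanamide on a pyrimidine scaffold

The compounds below may be only part of what the source reports. "The series", "measured", "known", "first", "only" and "open" are said of these compounds alone.

The account concerns two measured compounds and one that has not yet been measured. Compound 1 `CCC(=O)Nc1cc(Nc2ncc(Cl)c(N3CCc4sccc4C3)n2)c(OC)cc1N(C)CCN(C)C` carries a propanoylamino group on the anilino ring and gives 460 nM in a functional assay on A549 cells (Homo sapiens) for cytotoxicity, read by MTT assay; on this read-out lower numbers stand for stronger inhibition and higher numbers for weaker inhibition. Compound 2 `C=CC(=O)Nc1cc(Nc2ncc(Cl)c(N3CCc4sccc4C3)n2)c(OC)cc1N1CCN(C)CC1` differs from it at more than one place and gives 1560 nM in this assay. Among the two numbers, compound 1 holds the lower one, and the gap to compound 2 lies beyond the usual scatter of the measurement. No single-point comparison between measured compounds is available.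

Compound 3 `C/C=C/C(=O)Nc1cc(Nc2ncc(Cl)c(N3CCc4sccc4C3)n2)c(OC)cc1N(C)CCN(C)C` is derived from compound 1 by a single change: prop-1-en-1-yl in place of ethyl on a carbonyl carbon. The only shown contrast, between compound 1 and compound 2, involves several simultaneous differences. For the measured compounds named here, the isolated effect of this change therefore has no direct precedent here.

The expectation is a small step, if any, from compound 1 to compound 3 in this assay, likely not beyond the scatter, leaning toward a somewhat lower number: a 1.3-fold lower number from compound 1 to compound 3 (0.12 log units; within the scatter). Compound 3 is therefore estimated at 350 nM, with a plausible range from 120 nM to 1100 nM.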

Compound 3, half-maximal inhibitory concentration: 251 nM
Beside the measured number, compound 3's estimate is 1.4-fold (0.14 log units) above it, and the stated range covers the measured number.
By their numbers in this assay, from the lowest: compounds 3 and 1 (each within the scatter of the next); then compound 2.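

In this assay, prop-1-en-1-yl in place of ethyl on a carbonyl carbon gives a 1.8-fold lower number from compound 1 to compound 3 (0.26 log units; within the scatter), so this exchange leaves no difference that can be told from the scatter of the measurement. For the compounds shown here, this is the first comparison that isolates a single place, as compound 1 and compound 2 differ at more than one place and could not show what the group on this carbonyl carbon contributes on its own. No measurement shown here offers an explanation for this result, whether from the three-carbon group or from its double bond outside aromatic rings.

The exchange adds a carbon and a double bond together, and propyl on the same carbonyl carbon would be needed to separate the two, while a dimethylamino group at the end of the prop-1-en-1-yl or a longer chain such as butyl would show how much further this place can be altered. Compound 2 also leaves open how much of its gap from compound 1 in this assay belongs to the carbonyl substituent and how much to its other difference.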